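The source may report more compounds than this note shows. Statements on the series, on what has been measured and on what is new or still open speak of the compounds shown alone.

Compound 1 `O=C(/C=C/C(=O)N1C/C(=C\c2ccccc2)C(=O)/C(=C/c2ccccc2)C1)Nc1ccc(Cl)c(Cl)c1` gives 7500 nM.
Compound 2 `O=C(/C=C/C(=O)N1C/C(=C\c2ccc([N+](=O)[O-])cc2)C(=O)/C(=C/c2ccc([N+](=O)[O-])cc2)C1)Nc1ccc([N+](=O)[O-])cc1` gives 1000 nM.
Compound 3 `COc1ccc(NC(=O)/C=C/C(=O)N2C/C(=C\c3ccccc3)C(=O)/C(=C/c3ccccc3)C2)cc1` gives 6800 nM.

The three measured compounds were tested in a functional assay on L1210 cells (Mus musculus) for cytotoxicity; on this read-out lower numbers stand for stronger inhibition and higher numbers for weaker inhibition. Compound 2 stands lowest of the three numbers: its nearest neighbour is compound 3, and its furthest is compound 1, both beyond the scatter. Among the compounds with values here, compound 2 carries nitro groups on all three aryl rings, whereas compound 1 and compound 3 carry none on the benzylidene rings; no single-change step links compound 2 to either of them, so the two values can only be set side by side.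

Compound 4 `O=C(/C=C/C(=O)N1C/C(=C\c2ccc([N+](=O)[O-])cc2)C(=O)/C(=C/c2ccc([N+](=O)[O-])cc2)C1)Nc1ccccc1` has not yet been measured. It differs from compound 2 by hydrogen in place of nitro on an aromatic carbon. Within the data shown here, the one measured step that bears on a change at the anilide ring is a 1.1-fold lower number from compound 1 to compound 3 (0.04 log units; within the scatter), a swap of one aryl substituent pattern for another at the same amide-type nitrogen, which moved the number little. On that basis, removal of the nitro from the anilide ring of compound 2 is expected to change this assay only modestly, if at all, with a slight lean toward a higher number. Compound 4 is therefore estimated at 1500 nM, within 600 nM to 4000 nM, meaning a step of a 1.5-fold higher number from compound 2 to compound 4 (0.18 log units; within the scatter).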

Compound 4, half-maximal inhibitory concentration: 1800 nM
The estimate for compound 4 lay 1.2-fold (0.08 log units) below the measured number; low and high end bracket the measured number.
By their numbers in this assay, from the lowest: compounds 2 and 4 (each within the scatter of the next); then compounds 3 and 1 (each within the scatter of the next).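

In this assay the exchange of 4-nitrophenyl for phenyl on the amide-type nitrogen gives a 1.8-fold higher number from compound 2 to compound 4 (0.26 log units; within the scatter) and so does not separate compound 2 from compound 4. The earlier step at this nitrogen, a 1.1-fold lower number from compound 1 to compound 3 (0.04 log units; within the scatter), swapped one substituted phenyl for another in compounds without nitro on the other two aryl rings; the new step adds that the nitro group itself, para to a large group, can give way to hydrogen with no difference beyond the scatter, here with nitro kept on those two rings. No measurement shown here offers an explanation for this result.

The compounds shown leave open whether an amine or a carboxylic acid in place of the nitro at this position would also stay within the scatter of compound 2. Within the data shown here, they also leave open what the nitro groups on the other two aryl rings do to the number, as no single-change step links compound 4 to compound 1 or compound 3.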